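The source may report more compounds than this note shows. Statements on the series, on what has been measured and on what is new or still open speak of the compounds shown alone.

Measured so far in a functional assay on NCI-H460 cells (Homo sapiens) for cytotoxicity, read by MTT assay; on this read-out lower numbers stand for stronger inhibition and higher numbers for weaker inhibition:
- compound 1 `Cc1ccc(Nc2nc(C)c(C(=O)/C=C/c3ccc(Cl)cc3)s2)cc1` gives > 25000 nM, a limit of the assay rather than a number.
- compound 2 `Cc1cccc(Nc2nc(C)c(C(=O)/C=C/c3ccccc3)s2)c1` gives 21800 nM.
- compound 3 `Cc1cccc(Nc2nc(C)c(C(=O)/C=C/c3ccc(Cl)cc3)s2)c1` gives > 25000 nM, again a limit rather than a number.

Among the compounds with values here, compound 2 is thus the only member of the series with a number in this assay; the other two values sit at the limit of > 25000 nM in this assay, at which 2 of the 3 values shown sit. Compound 4 `Cc1ccc(Nc2nc(C)c(C(=O)/C=C/c3ccccc3)s2)cc1` differs from compound 2 by 4-methylphenyl in place of 3-methylphenyl on a nitrogen on an aromatic ring, the same atoms joined differently.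

Within the data shown here, two measured steps bear on this. The one of the same kind, a step that the two limits leave unreadable from compound 1 to compound 3, runs between two limits and so gives no size at all. The other, an at least 1.1-fold higher number from compound 2 to compound 3 (0.05 log units; that floor lies within the scatter), concerns a different change, and its floor lies within the scatter. No readable precedent for the change to compound 4 therefore exists. The expectation is a step of a 1.0-fold higher number from compound 2 to compound 4 (0.00 log units; within the scatter), none beyond the scatter. Compound 4 is estimated at 22000 nM, between 10000 nM and 50000 nM, with a fair chance that only a limit is reported.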

Compound 4, half-maximal inhibitory concentration: > 25000 nM
Compound 4: a limit, no number; the forecaster's own chance of this, stated with the estimate: 45%; middle value at least 1.1-fold (0.05 log units) from the limit.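

In this assay compound 4 gives > 25000 nM as a limit of the assay and not a number. The change from 3-methylphenyl to 4-methylphenyl on a nitrogen on an aromatic ring now has its first readable step, an at least 1.1-fold higher number from compound 2 to compound 4 (0.05 log units; that floor lies within the scatter) and this is only a floor, so it shows neither a real gap nor the absence of one, while the steps that run between two limits cannot be read. (With compound 4 the series gathers further at one ceiling: the limit of > 25000 nM in this assay, at which 3 of the 4 values shown sit)

On these data alone, how far compound 4 and the chloro compounds lie past that limit stays open, so the two methylphenyl placings cannot yet be ranked. Also open, as far as these compounds go, is whether an amine or a carboxylic acid in place of the methyl on this phenyl ring would give a number clearly under the limit.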